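The compounds below may be only part of what the source reports. "The series", "measured", "known", "first", "only" and "open" are said of these compounds alone.

Compound 3 `COc1cc(Oc2cccc(Nc3ccccc3)c2)cc(OC)c1CNCCNC(C)=O` holds the highest number among the three measured compounds: in a functional assay on HCT-116 cells (Homo sapiens) for inhibition, read by MTT assay, with a stated time of 72 h (a higher number here means a weaker inhibitor, a lower number a stronger inhibitor), compound 3 gives 18200 nM, whereas compound 1 `COc1ccc(CNCc2c(OC)cc(Oc3cccc(Nc4ccccc4)c3)cc2OC)cc1` gives 2620 nM and compound 2 `COc1cc(Oc2cccc(Nc3ccccc3)c2)cc(OC)c1CNCc1ccc(F)cc1` gives 4220 nM. The step to compound 4 `COc1cc(Oc2cccc(Nc3ccccc3)c2)cc(OC)c1CNCc1ccc(C)cc1` is 4-methylphenyl in place of acetamidomethyl on a saturated chain carbon bound to an amine nitrogen. Going by the values given here, two measured steps bear directly on it, each running the opposite way: a 6.9-fold higher number from compound 1 to compound 3 (0.84 log units; beyond the scatter) and a 4.3-fold higher number from compound 2 to compound 3 (0.63 log units; beyond the scatter). Replacing the acetamidomethyl with an aryl group in the same place has thus twice lowered the number beyond the scatter, and a 4-methylphenyl is expected to behave like the 4-methoxyphenyl and 4-fluorophenyl already seen. Compound 4 is therefore estimated at 3200 nM, in the range 1300 nM to 8000 nM, which is the expected step of a 5.7-fold lower number from compound 3 to compound 4 (0.75 log units; beyond the scatter).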

Compound 4, half-maximal inhibitory concentration: 13800 nM
Beside the measured number, compound 4's estimate is 4.3-fold (0.63 log units) below it; measured number outside the range, above it.
By their numbers in this assay, from the lowest: compounds 1 and 2 (each within the scatter of the next); then compounds 4 and 3 (each within the scatter of the next).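

In this assay, the step of a 1.3-fold lower number from compound 3 to compound 4 (0.12 log units; within the scatter) shows that an aryl group in place of acetamidomethyl does not always lower the number: 4-methylphenyl goes against the pattern set by 4-methoxyphenyl and 4-fluorophenyl. The group on the aromatic carbon now makes a difference, with methyl giving a 3.3-fold higher number from compound 2 to compound 4 (0.51 log units; beyond the scatter) against fluoro and a 5.3-fold higher number from compound 1 to compound 4 (0.72 log units; beyond the scatter) against methoxy. No evidence on the cause is at hand. As far as these compounds go, it remains open whether chloro, hydroxy or plain hydrogen on that aromatic carbon would track with methyl or with methoxy and fluoro.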